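The source may hold more compounds than are shown below. What is called first, only, known or untested is meant among the compounds shown, and "the series" means these compounds.

Three compounds here share one core and differ in a single group. In a functional assay on HCT-116 cells (Homo sapiens) for antiproliferative activity, read by MTT assay, with a stated time of 72 h (a lower number here means a stronger inhibitor, a higher number a weaker inhibitor), compound 1 (`COc1ccc(OCCCON2C(N)=NC(N)=NC23CCOCC3)cc1`) gives 1500 nM while compound 2 (`Cc1cc(C)cc(OCCCON2C(N)=NC(N)=NC23CCOCC3)c1`) gives the lower number of the two (190 nM) and so stands first so far. For the measured compounds named here, the one measured step (a 7.9-fold lower number from compound 1 to compound 2 (0.90 log units; beyond the scatter)) changes only the group on an oxygen on a saturated carbon, and it lies beyond the usual scatter.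

Compound 3 (`NC1=NC2(CCOCC2)N(OCCCOc2cccc(Br)c2)C(N)=N1`) changes that same place again, with 3-bromophenyl in place of 3,5-dimethylphenyl on an oxygen on a saturated carbon. Going by the values given here, no measured compound carries bromine, and a single step shows no trend, so the earlier step serves only as a rough gauge of how far a change here can move the number. With compound 2 at the low end (190 nM) a small rise in this assay is expected, smaller than the earlier step and perhaps no larger than the scatter. The expected change is a 1.6-fold higher number from compound 2 to compound 3 (0.20 log units; within the scatter) on this reasoning. For compound 3 the estimated value is 300 nM (expected range 90 nM to 1000 nM) in this test of cell growth.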

Compound 3, half-maximal inhibitory concentration: 40 nM
The estimate for compound 3 lay 7.5-fold (0.88 log units) above the measured number, outside the stated range (below it).
By their numbers in this assay, from the lowest: compound 3; then compound 2; then compound 1.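

The group on an oxygen on a saturated carbon still had room to lower the number in this assay, and a 4.8-fold lower number from compound 2 to compound 3 (0.68 log units; beyond the scatter) shows that 3,5-dimethylphenyl did not mark the low end at this place. Across the three groups the span widens to a 38-fold lower number from compound 1 to compound 3 (1.57 log units; beyond the scatter), a large change that comes from this one place while the shared core stays the same. The swap from 3,5-dimethylphenyl to 3-bromophenyl takes the group from 8 heavy atoms to 7 and leaves one six-membered aromatic ring with no hydrogen-bond donors or acceptors, but no measurement here bears on why the number fell.

The compounds shown leave open whether the lower number goes with the bromine itself or with the pattern of a single group on the ring, a question that a 3-chlorophenyl group in this place could help to settle. They also leave open how a carboxylic acid or an amine on the ring would move the number in this assay.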